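Trading an isobutyl for a pyrazole on the amide nitrogen

The source may hold more compounds than are shown below. What is called first, only, known or untested is meant among the compounds shown, and "the series" means these compounds.

Measured so far:
compound 1, `Cc1ccc(OCC(=O)N(Cc2cccs2)CC(C)C)cc1`: 900 nM
compound 2, `CCN(Cc1nccs1)C(=O)COc1ccc(C)cc1`: 3060 nM

Of the compounds shown here, two share an aryloxyacetamide core and have been tested in an assay on HEK293 cells for agonist activity at transient receptor potential cation channel subfamily M member 8 (Homo sapiens), read by fluorescence and calcium flux, with a stated time of 15 min; a higher number here means that more compound is needed for the effect, a lower number that less compound is needed. In this assay compound 1 gives 900 nM, the lower of the two numbers, so less of it is needed for the effect. In this assay compound 2 gives 3060 nM, a gap from compound 1 that lies beyond the usual scatter of repeated measurements. Among the compounds with values here, compounds 1 and 2 differ in more than one place, so no single step between them can be read out.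

The next compound, compound 3 with structure `Cc1ccc(OCC(=O)N(Cc2cccs2)c2c(C)n[nH]c2C)cc1`, is built from compound 1 by one change: 3,5-dimethyl-1H-pyrazol-4-yl in place of isobutyl on an amide-type nitrogen. A branched chain with no donor or acceptor gives way to an aromatic ring carrying one of each. Within the data shown here, no measured pair shows such an exchange, so the size of the step is open. The expectation is that the number rises, meaning more compound is needed, by a step of roughly a 3.3-fold higher number from compound 1 to compound 3 (0.52 log units; beyond the scatter). For compound 3 the estimated result in this assay is 3000 nM, with a likely range from 800 nM to 12000 nM.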

Compound 3, half-maximal effective concentration: 0.3 nM
For compound 3 the middle estimate is 10000-fold (4.00 log units) above the measured one, and the stated range ends above it.
By their numbers in this assay, from the lowest: compound 3; then compound 1; then compound 2.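

Putting 3,5-dimethyl-1H-pyrazol-4-yl in place of isobutyl on the amide-type nitrogen gives, in this assay, a 3000-fold lower number from compound 1 to compound 3 (3.48 log units; beyond the scatter), a large step well beyond the scatter. This shows that the group on this nitrogen has a very strong hold on the read-out, and that a single exchange here can turn a compound needed in modest amounts into one needed in far smaller amounts. Nothing on hand accounts for a step of this size.

The compounds shown leave open which part of the entering group goes with the step: the aromatic ring itself, its two methyl groups, or its ring nitrogens with the one donor and one acceptor counted there; a plain phenyl ring or a pyrazole without the two methyl groups on this nitrogen would begin to separate these. On these data alone, it also remains open whether the same exchange would bring a similar step on the core of compound 2, which carries a different set of groups elsewhere.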